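This account rests on a few compounds, and the source may have more. Where it says the series, first, only, none or still open, it means among the compounds named here.

Measured compounds:
- compound 1, `CCOC(=O)C1=C(C)NC(=S)NC1c1cc(OC)c(O)c(OC)c1`: 1.9 ug/mL
- compound 2, `CCOC(=O)C1=C(C)NC(=O)NC1c1ccc(O)cc1`: 27.3 ug/mL
- compound 3, `CCOC(=O)C1=C(C)NC(=S)NC1c1ccc(SC)cc1`: 8.5 ug/mL

In a functional assay on OVCAR-3 cells (Homo sapiens) for inhibition, read by sulforhodamine B assay, with a stated time of 48 h (on this read-out lower numbers stand for stronger inhibition of growth and higher numbers for weaker inhibition of growth), compound 1 gives 1.9 ug/mL, the lowest of the three numbers. Compound 3 comes nearest to it with 8.5 ug/mL, a gap beyond the scatter; compound 2, with 27.3 ug/mL, is the furthest away. Compound 4, `CCOC(=O)C1=C(C)NC(=S)NC1c1ccc(O)c(OC)c1`, has not been measured. It differs from compound 1 in one place: hydrogen in place of methoxy on an aromatic carbon. For the measured compounds named here, no pair of measured compounds shows this exact change, so the step in this assay must be guessed. A small loss is expected, a step from compound 1 to compound 4 of a 1.8-fold higher number from compound 1 to compound 4 (0.27 log units; within the scatter) that may not clear the scatter. Compound 4 is therefore estimated at 3.5 ug/mL, with a range from 1.2 ug/mL to 10 ug/mL.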

Compound 4, concentration for 50% growth inhibition: 11 ug/mL
Compound 4: the middle estimate sits 3.1-fold (0.50 log units) below what was measured, outside the stated range (above it).
By their numbers in this assay, from the lowest: compound 1; then compounds 3 and 4 (each within the scatter of the next); then compound 2.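

In this assay hydrogen in place of methoxy on an aromatic carbon, ortho to a hydroxy group, gives a 5.8-fold higher number from compound 1 to compound 4 (0.76 log units; beyond the scatter) and so shows that this methoxy group counts towards growth inhibition. The earlier compounds shown here could not show this, as no two of them differed in only one place. Nothing available explains the loss.

On these data alone, only methoxy and hydrogen can be compared at this position, so it remains open whether an ethoxy group, a fluorine atom or an amine would keep the lower number of compound 1.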